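Amide in place of cyclohexylmethyl on the piperidine-type amine

The source may hold more compounds than are shown below. What is called first, only, known or untested is meant among the compounds shown, and "the series" means these compounds.

Three compounds of a shared core have been examined in an in vitro functional assay on RBL cells for antagonist activity at C-C chemokine receptor type 8 (Homo sapiens), read by FLIPR and calcium flux; on this read-out higher numbers stand for weaker inhibition and lower numbers for stronger inhibition. Compound 1 `COc1ccc2nccc(C3CN(C4CCN(Cc5cc6ccccc6[nH]5)C4)C(=O)O3)c2c1` gives only a limit of the assay, < 50200 nM. Compound 2 `O=C1OC(c2ccnc3ccccc23)CN1C1CCN(Cc2cc3ccccc3[nH]2)CC1` gives 1000 nM in this assay. Compound 3 `COc1ccc2nccc(C3CN(C4CCN(CC5CCCCC5)CC4)C(=O)O3)c2c1`, whose amine nitrogen in a ring carries a cyclohexylmethyl group, gives 7940 nM in this assay, the highest of the two numbers that were obtained; the value of compound 2 is the nearest and lies well beyond the usual scatter from it. Compound 4 `COc1ccc2nccc(C3CN(C4CCN(C(=O)c5ccc(Cl)c(Cl)c5)CC4)C(=O)O3)c2c1` has not been measured. It differs from compound 3 in one place: (3,4-dichlorophenyl)carbonyl in place of cyclohexylmethyl on an amine nitrogen in a ring. For the measured compounds named here, no step between two measured compounds with such a change is available. He expects compound 4 to sit at a weaker level, an estimate of 20000 nM in this assay with a range from 4000 nM to 60000 nM. The step he expects from compound 3 to compound 4, a 2.5-fold higher number from compound 3 to compound 4 (0.40 log units; beyond the scatter), is estimated to reach beyond the scatter.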

Compound 4, half-maximal inhibitory concentration: 6310 nM
For compound 4 the middle estimate is 3.2-fold (0.50 log units) above the measured one; measured number inside the range.
By their numbers in this assay, from the lowest: compound 2; then compounds 4 and 3 (each within the scatter of the next).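

For the compounds shown here, the step of a 1.3-fold lower number from compound 3 to compound 4 (0.10 log units; within the scatter) in this assay is the first reading at this position, on the amine nitrogen in a ring, and it replaces cyclohexylmethyl with (3,4-dichlorophenyl)carbonyl. In this one pair, a carbon-only non-aromatic ring and an aromatic ring carried on a carbonyl cannot be told apart, even though the entering group brings a hydrogen-bond acceptor and the chlorine atoms. Nothing given here bears on why the two compounds read alike.

The compounds shown leave open whether a plain benzyl, an acetyl or a chain ending in a carboxylic acid on this nitrogen would move the number beyond the scatter. They also leave open what the chlorine atoms contribute, and whether an unsubstituted benzoyl group would read the same.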